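The source may report more compounds than this note shows. Statements on the series, on what has been measured and on what is new or still open speak of the compounds shown alone.

Measured compounds:
compound 1, `Nc1cc(N)c2nc(-c3ccccc3)c(Oc3ccc(Cl)c(Cl)c3)nc2c1`: < 100000 nM
compound 2, `CCOC(=O)[C@H](CCC(=O)O)NC(=O)c1ccc(Sc2nc3cc(N)cc(N)c3nc2-c2ccccc2)cc1`: 87100 nM
compound 3, `CCOC(=O)[C@H](CCC(=O)O)NC(=O)c1ccc(Oc2nc3cc(N)cc(N)c3nc2-c2ccccc2)cc1`: 58900 nM

In a functional assay on UACC-62 cells (Homo sapiens) for inhibition, read by sulforhodamine B assay, with a stated time of 48 h (a higher number here means that more compound is tolerated, a lower number that less compound is tolerated), compound 1 gives < 100000 nM, and this is a limit of the assay rather than a measured number. The record for compound 1 is therefore only (the limit of < 100000 nM in this assay, at which 1 of the 3 values shown sits), so its true position on the scale is not known. The other two measured compounds share the same core and carry a larger group at the same position: compound 2 gives 87100 nM and compound 3 gives 58900 nM in this assay.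

Compound 4, `Nc1cc(N)c2nc(-c3ccccc3)c(Sc3ccc(Cl)c(Cl)c3)nc2c1`, has not yet been measured in this assay. It differs from compound 1 in one place, ((3,4-dichlorophenyl)sulfanyl in place of 3,4-dichlorophenoxy on an aromatic carbon). Within the data shown here, no step between measured compounds of this set has been worked out, so there is nothing to lean on for the size of the change; the expectation in this assay is a step of no size beyond the scatter, in either direction. Compound 4 is estimated at 60000 nM, within 20000 nM to 150000 nM, meaning an expected step that the limit leaves unreadable from compound 1 to compound 4.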

Compound 4, concentration lethal to 50% of the cells: < 100000 nM
Compound 4: no number, only a limit (the forecaster's own chance of this, stated with the estimate: 35%); the middle value is on the limit's open side.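

In this assay, among these compounds, compound 1 and compound 4 each stand only at a limit of the assay, not at a number, so no step between them can be read. The compounds shown leave open whether (3,4-dichlorophenyl)sulfanyl in place of 3,4-dichlorophenoxy changes the result at all.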